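This account rests on a few compounds, and the source may have more. Where it says the series, first, only, none or still open, it means among the compounds named here.

Compound 1, `COc1ccc(SCc2ccc(/C=C/C(=O)Nc3ccccc3N)cc2)cc1OC`, shows 80.6% in a functional assay on A549 cells (Homo sapiens) for inhibition, read by CCK-8 assay, with a stated time of 72 h, tested at 8 uM (a lower number here means less inhibition of growth, a higher number more inhibition of growth at the concentration tested), the lower of the two numbers recorded. Compound 2, `Nc1ccccc1NC(=O)c1ccc(CSc2nccc(C(F)(F)F)n2)cc1`, gives 95.1% in this assay, a value above that of compound 1 by more than the usual scatter. Compound 3, `Nc1ccccc1NC(=O)/C=C/c1ccc(CSc2cccc3ccccc23)cc1`, has not yet been tested. It differs from compound 1 by naphthalen-1-yl in place of 3,4-dimethoxyphenyl on a sulfur. For the measured compounds named here, no measured pair mirrors this exchange, so the step is expected to stay within the scatter, with no clear direction. The growth inhibition from compound 1 to compound 3 is therefore estimated at a number 1.4 percentage points higher from compound 1 to compound 3 (within the scatter). For compound 3 the estimate is 82%, between 65% and 95%.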

Compound 3, percent growth inhibition at one concentration: 71.2%
Beside the measured number, compound 3's estimate is 10.8 percentage points above it; measured number inside the range.
By their numbers in this assay, from the lowest: compounds 3 and 1 (each within the scatter of the next); then compound 2.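

With naphthalen-1-yl in place of 3,4-dimethoxyphenyl on a sulfur, the result in this assay is a number 9.4 percentage points lower from compound 1 to compound 3 (within the scatter). At this position, then, a second aromatic ring of carbon only, together with the loss of both oxygens, brings no change that can be told from the scatter. No available evidence bears on this step.

Compound 2 differs from both compounds in more than one place, so it cannot separate the two parts of this exchange. As far as these compounds go, what a plain phenyl, a cyclohexyl or a carboxylic acid would do at this sulfur remains open.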